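Replacing 2-(methoxycarbonyl)ethenyl with 2-carboxyethyl on the shared core

A few compounds are considered here, and "the series" means these few. Any claim that something is new, unique, unknown or untested is made for them only; others in the source may bear on it.

Within the data shown here, only two compounds in this small series have been measured so far, and just one of them has returned an actual number. In a functional assay on MCF7 cells (Homo sapiens) for inhibition, read by sulforhodamine B assay, with a stated time of 72 h (a lower number here means a stronger inhibitor of growth, a higher number a weaker inhibitor of growth), compound 2 (`COC(=O)/C=C/c1ccncc1-c1ccc2ccccc2c1`) gives 8170 nM as the only number shown. In this assay compound 1 (`O=C(CCc1ccncc1-c1ccc2ccccc2c1)N1CCOCC1`) reads > 10000 nM, which is a limit of the measurement and not a number.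

The next compound is compound 3 (`O=C(O)CCc1ccncc1-c1ccc2ccccc2c1`). It has 2-carboxyethyl in place of 2-(methoxycarbonyl)ethenyl on an aromatic carbon, on a six-membered aromatic ring with 1 nitrogen, ortho to a large group and opposite the ring nitrogen, and the count of this change is 2-carboxyethyl in place of 2-(methoxycarbonyl)ethenyl on an aromatic carbon in full.

Among the measured compounds shown here, no measured step bears directly on this change. Only a small shift is therefore expected in this assay, towards weaker growth inhibition or none beyond the scatter, since compound 2 at 8170 nM is already a weak inhibitor of growth. The estimated step of a 1.2-fold higher number from compound 2 to compound 3 (0.09 log units; within the scatter) is accordingly modest. Compound 3 is estimated at 10000 nM, with an expected range from 4000 nM to 25000 nM and a fair chance that only a limit is reported.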

Compound 3, concentration for 50% growth inhibition: > 10000 nM
Compound 3 gave a limit, no number; the forecaster's own chance of this, stated with the estimate: 65%; the middle value lies on the limit itself.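

Placing 2-carboxyethyl in place of 2-(methoxycarbonyl)ethenyl on this aromatic carbon, opposite the ring nitrogen, gives an at least 1.2-fold higher number from compound 2 to compound 3 (0.08 log units; that floor lies within the scatter), so this first direct test of the position shows no gain in growth inhibition from the change. In this assay compound 3 gives > 10000 nM, which is a limit of the assay and not a number. The step from compound 1 to compound 3 cannot be read, so the swap of morpholin-4-yl for hydroxy on the carbonyl carbon shows no measurable effect either way, and the series now rests largely on one ceiling: the limit of > 10000 nM in this assay, at which 2 of the 3 values shown sit.

The compounds shown leave open how far compound 3 actually lies from compound 2, and they do not separate the loss of the chain double bond from the replacement of the methyl ester by a carboxylic acid, which a 2-(methoxycarbonyl)ethyl or a 2-carboxyethenyl group at the same place would do. They also leave open whether an amine or a longer chain at this position would bring a stronger inhibitor of growth.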